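Serum half-life of phosphate diesters on a shared core

This account rests on a few compounds, and the source may have more. Where it says the series, first, only, none or still open, it means among the compounds named here.

The shared core is seen in compound 2 `O=C(O[C@H]1C[C@H](n2cc(F)c(=O)[nH]c2=O)O[C@@H]1COP(=O)(O)Oc1cccnc1)c1ccccc1`; compound 1 `CCCCCCCCCc1ccc(OP(=O)(O)OC[C@H]2O[C@@H](n3cc(F)c(=O)[nH]c3=O)C[C@@H]2OC(=O)c2ccccc2)cc1` and compound 3 `O=C(O[C@H]1C[C@H](n2cc(F)c(=O)[nH]c2=O)O[C@@H]1COP(=O)(O)Oc1ccc2ncccc2c1)c1ccccc1` differ from it only in the group attached through an oxygen. In an ADME assay on a cell-free system (serum, Homo sapiens) for metabolic stability, read by HPLC, tested at 2 mM (a higher number here means that the compound lasts longer, a lower number that the compound disappears faster), compound 2 gives 17.8 h. Compound 3 gives 16.5 h, a step of a 1.1-fold lower number from compound 2 to compound 3 (0.03 log units; within the scatter). For compound 1 the value > 120 h is a limit of the assay and not a number (the limit of > 120 h in this assay, at which 1 of the 3 values shown sits). Of the two numbers in hand, compound 2 stands highest, though its gap to compound 3 lies within the scatter, so no order between the two can be read.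

Compound 4 `C[N+]1(C)CCC(OP(=O)([O-])OC[C@H]2O[C@@H](n3cc(F)c(=O)[nH]c3=O)C[C@@H]2OC(=O)c2ccccc2)CC1` is not yet measured. Relative to compound 2 it carries a group of 12 heavy atoms (7 carbon, 1 nitrogen, 3 oxygen, 1 phosphorus; one six-membered non-aromatic ring with 1 hetero atom) in place of a group of 10 heavy atoms (5 carbon, 1 nitrogen, 3 oxygen, 1 phosphorus; one six-membered aromatic ring with 1 hetero atom), on an oxygen on a saturated carbon. For the measured compounds named here, the one measured step, from compound 2 to compound 3, swaps one aromatic group for another and stayed within the scatter; no measured step exchanges an aromatic ring for a non-aromatic one at this oxygen. With nothing bearing directly on the change, no shift beyond the scatter is firmly expected, and the range has to stay wide in both directions. Compound 4 is expected to give about 30 h, between 8 h and 120 h. That estimate means an expected step of a 1.7-fold higher number from compound 2 to compound 4 (0.23 log units; within the scatter).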

Compound 4, half-life: > 120 h
Compound 4: a limit, no number (the forecaster's own chance of this, stated with the estimate: 20%); middle value at least 4.0-fold (0.60 log units) from the limit.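

In this assay, for the compounds shown here, this oxygen turns out to be a place where a change can move the half-life beyond the scatter: the exchange of the aromatic group for the non-aromatic one gives an at least 6.7-fold higher number from compound 2 to compound 4 (0.82 log units; beyond the scatter), whereas the one earlier step between two numbers, a 1.1-fold lower number from compound 2 to compound 3 (0.03 log units; within the scatter), stayed within it. Going by these compounds, compound 4 gives > 120 h, which is a limit of the assay and not a number, so the true size of the step stays unknown. Compound 4 now sits at the same limit as compound 1, which carries an aromatic ring at this oxygen, so reaching that limit does not require a non-aromatic ring here: the limit of > 120 h in this assay, at which 2 of the 4 values shown sit.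

With both compounds at the limit, no order between compound 1 and compound 4 can be read. On these data alone, it also stays open which part of the entering group goes with the longer half-life, the non-aromatic ring or its nitrogen, and whether a cyclohexyl group, with the same ring size but only carbon in the ring, or a short alkyl chain on this oxygen would reach the same limit.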